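Fluoro gives way to trifluoromethyl in compound 2

This account rests on a few compounds, and the source may have more. Where it says the series, first, only, none or still open, it means among the compounds named here.

In a functional assay on SMMC-7721 cells (Homo sapiens) for cytotoxicity, read by MTT assay, with a stated time of 24 h (on this read-out lower numbers stand for stronger inhibition and higher numbers for weaker inhibition), compound 1 `O=C1/C(=C/c2cccnc2)CN(S(=O)(=O)c2ccccc2)C/C1=C\c1ccccc1F` gives 19100 nM and compound 2 `Cc1ccc(S(=O)(=O)N2C/C(=C\c3cccnc3)C(=O)/C(=C/c3ccccc3F)C2)cc1` gives 10300 nM, which lie within the scatter of each other. Compound 3 `O=C1/C(=C/c2cccnc2)CN(S(=O)(=O)c2ccc([N+](=O)[O-])cc2)C/C1=C\c1ccccc1F` gives > 20000 nM, which is a limit of the assay. Compound 4 `Cc1ccc(S(=O)(=O)N2C/C(=C\c3cccnc3)C(=O)/C(=C/c3ccccc3C(F)(F)F)C2)cc1` differs from compound 2 by trifluoromethyl in place of fluoro on an aromatic carbon. Within the data shown here, no measured step changes that group, so the only guides are indirect: a 1.9-fold lower number from compound 1 to compound 2 (0.27 log units; within the scatter), an at least 1.0-fold higher number from compound 1 to compound 3 (0.01 log units; that floor lies within the scatter) and an at least 1.9-fold higher number from compound 2 to compound 3 (0.28 log units; that floor lies within the scatter). With these steps as the guide, only a small change without a clear direction is expected, namely a 1.1-fold lower number from compound 2 to compound 4 (0.06 log units; within the scatter). The estimate for compound 4 is 9000 nM, with an expected range from 3500 nM to 20000 nM.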

Compound 4, half-maximal inhibitory concentration: 6700 nM
Estimate against measurement, compound 4: 1.3-fold (0.13 log units) above; measured number inside the range.
By their numbers in this assay, from the lowest: compounds 4, 2 and 1 (each within the scatter of the next, the first and the last beyond it). At a limit, above all of these: compound 3.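

Trifluoromethyl in place of fluoro, on an aromatic carbon ortho to a large group, gives a 1.5-fold lower number from compound 2 to compound 4 (0.19 log units; within the scatter). Among these compounds, this is the first reading at this position: in this assay, four heavy atoms stand in place of one, and the numbers of the two compounds stay within the scatter of each other. Nothing measured here bears on this result. The compounds shown leave open whether an amine or a carboxylic acid at this position would move the number beyond the scatter, and whether the same step would hold on the core of compound 1.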